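A Second Chloro Group in a Series at the Assay Limit

The source may hold more compounds than are shown below. What is called first, only, known or untested is meant among the compounds shown, and "the series" means these compounds.

Compound 1 `ClCc1ccccc1Cn1cnc2c(Cl)ncnc21`: > 100000 nM
Compound 2 `ClCc1cccc(Cn2cnc3ncnc(Cl)c32)c1`: > 100000 nM
Compound 3 `ClCc1ccccc1Cn1cnc2ncnc(Cl)c21`: > 100000 nM

Three compounds share a chloromethyl-substituted aromatic ring attached through a methylene to a fused bicyclic core bearing a chloro group. In a functional assay on HT-29 cells (Homo sapiens) for cytotoxicity, read by sulforhodamine B assay, with a stated time of 48 h (a lower number here means a stronger inhibitor of growth, a higher number a weaker inhibitor of growth), compound 1 gives > 100000 nM, which is a limit of the assay and not a number. Compound 2 likewise gives > 100000 nM in this assay, again a limit. Compound 3 gives > 100000 nM in this assay, also only a limit. Compound 3 therefore stands nowhere in particular among the numbers shown, since the limit of > 100000 nM in this assay, at which 3 of the 3 values shown sit, and no value is distinguished from another.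

Compound 4 `ClCc1ccccc1Cn1cnc2nc(Cl)nc(Cl)c21` differs from compound 3 by chloro in place of hydrogen on an aromatic carbon. Among the compounds with values here, no step between measured compounds is available. The three limits give no indication that this assay responds to changes of this kind within the series, so the step from compound 3 to compound 4 is expected to fall within the scatter, if any number is reached at all, with a step that the limit leaves unreadable from compound 3 to compound 4 expected. Compound 4 is estimated at 150000 nM, between 30000 nM and 600000 nM, most likely reported as a limit again.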

Compound 4, concentration for total growth inhibition: > 100000 nM
Compound 4: only a limit was reported; the forecaster's own chance of this, stated with the estimate: 80%; the middle value does not contradict the limit.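

Like compound 3, compound 4 gives only a limit, so no step can be read between them: the limit of > 100000 nM in this assay, at which 4 of the 4 values shown sit. The compounds shown leave open whether chloro in place of hydrogen on an aromatic carbon changes growth inhibition at all.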